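Methylating the Ring Nitrogen in a Small Amine Oxidase Series

The compounds below may be only part of what the source reports. "The series", "measured", "known", "first", "only" and "open" are said of these compounds alone.

Measured in an assay for inhibition of Amine oxidase [flavin-containing] A (Bos taurus), read by fluorescence; a lower number here means a stronger inhibitor, a higher number a weaker inhibitor:

compound 1 `O=C(NCCCCc1ccccc1)c1cc2ccccc2[nH]1` — 2200 nM
compound 2 `CN(CCCCc1ccccc1)C(=O)c1cc2ccccc2n1C` — 1000 nM
compound 3 `CN(Cc1ccccc1)Cc1cc2ccccc2[nH]1` — 60 nM

Within the data shown here, compound 3 gives the lowest number of the three; compound 1 and compound 2 both sit higher, each beyond the usual scatter, so compound 3 is the most potent compound so far. Compound 4 `CN(Cc1ccccc1)Cc1cc2ccccc2n1C` is the next compound, differing from compound 3 by methyl in place of hydrogen on an aromatic nitrogen. Among the measured compounds shown here, no pair among the measured compounds differs in one place only, so the size of this change has not been measured directly. Compound 1 and compound 2 differ in two places, one of them a methyl on the same aromatic nitrogen, and their two values differ only moderately. The step from compound 3 to compound 4 is therefore expected to be small, no change at the digits printed from compound 3 to compound 4 (within the scatter), with no clear direction beyond the scatter. Compound 4 is estimated at 60 nM, with a range from 20 nM to 180 nM.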

Compound 4, inhibition constant: 7200 nM
Estimate against measurement, compound 4: 120-fold (2.08 log units) below, and the stated range ends below it.
By their numbers in this assay, from the lowest: compound 3; then compound 2; then compound 1; then compound 4.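

In this assay, among these compounds, methyl in place of hydrogen on the aromatic nitrogen gives a 120-fold higher number from compound 3 to compound 4 (2.08 log units; beyond the scatter) and is the first single change read directly. At this position, next to the ring atom that bears a large group, one added carbon moves the series from its lowest number to its highest, so this hydrogen cannot be replaced freely in this pair. Nothing available accounts for the size of the step.

Going by these compounds, whether an ethyl group or a longer chain on this nitrogen behaves like methyl remains open. So does the size of this same step among compounds carrying the amide linker.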